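A few compounds are considered here, and "the series" means these few. Any claim that something is new, unique, unknown or untested is made for them only; others in the source may bear on it.

Three compounds of this set carry a number in a functional assay on ACHN cells (Homo sapiens) for inhibition, read by sulforhodamine B assay, with a stated time of 48 h; a higher number here means a weaker inhibitor of growth, a lower number a stronger inhibitor of growth. Compound 1 `COc1cc(-c2nn(-c3cccc(NC(=O)c4cccc(C(F)(F)F)c4)c3)cc2-c2ccncc2)ccc1Cl` gives 1890 nM, the highest of the three. Compound 2 `O=C(Nc1cccc(-n2cc(-c3ccncc3)c(-c3ccc(Cl)c(O)c3)n2)c1)Nc1cc(C(F)(F)F)cc(C(F)(F)F)c1` gives 624 nM, and compound 3 `O=C(Nc1cccc(-n2cc(-c3ccncc3)c(-c3ccc(Cl)c(O)c3)n2)c1)Nc1ccc(Cl)c(C(F)(F)F)c1` gives 913 nM; both differ from compound 1 in more than one place, so their lower numbers cannot be tied to any single change. Compound 4 `COc1cc(-c2nn(-c3cccc(NC(=O)Nc4ccc(Cl)c(Cl)c4)c3)cc2-c2ccncc2)ccc1Cl` is not yet measured. It differs from compound 1 in one place only: (3,4-dichlorophenyl)amino in place of 3-(trifluoromethyl)phenyl on a carbonyl carbon. Compounds 2 and 3 share this kind of change at the carbonyl carbon, though each differs elsewhere as well, and both sit beyond the scatter below compound 1; that is the only pointer available. The step from compound 1 to compound 4 is expected to be a 2.1-fold lower number from compound 1 to compound 4 (0.32 log units; beyond the scatter), toward a lower number, beyond the scatter but modest. For compound 4 in this assay the estimate is 900 nM, with a range from 350 nM to 2300 nM.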

Compound 4, concentration for 50% growth inhibition: 1000 nM
Compound 4: middle estimate off by 1.1-fold (0.05 log units), on the low side, within the range that was stated.
By their numbers in this assay, from the lowest: compounds 2, 3, 4 and 1 (each within the scatter of the next, the first and the last beyond it).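

Read at the carbonyl carbon in this assay, (3,4-dichlorophenyl)amino in place of 3-(trifluoromethyl)phenyl gives a 1.9-fold lower number from compound 1 to compound 4 (0.28 log units; within the scatter), the first reading of this change on its own. The step does not separate the two groups, so at this position the swap alone shows no resolved effect on growth inhibition. No supporting measurement bears on the reading of this step.

Open, going by these compounds, is whether the lower numbers of compounds 2 and 3 owe anything to this position. Also open, on these data alone, is how a piperidine or a carboxylic acid would read on this carbonyl carbon.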